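Ring-closed ester in place of a linear octanoyl chain

A few compounds are considered here, and "the series" means these few. Any claim that something is new, unique, unknown or untested is made for them only; others in the source may bear on it.

In a functional assay (Oryctolagus cuniculus) for inhibition of platelet-activating factor receptor (Cavia porcellus) (a higher number here means a weaker inhibitor, a lower number a stronger inhibitor), compound 2 `CCCCCCCC(=O)OCC1CN(C(=O)c2cc(OC)c(OC)c(OC)c2)CCN1C(=O)c1cc(OC)c(OC)c(OC)c1` gives 310 nM, the higher of two numbers, with compound 1 `CCCCCC(=O)OCC1CN(C(=O)c2cc(OC)c(OC)c(OC)c2)CCN1C(=O)c1cc(OC)c(OC)c(OC)c1` nearest at 290 nM; the step of a 1.1-fold higher number from compound 1 to compound 2 (0.03 log units; within the scatter) stays within the scatter. Among the compounds with values here, compound 3 `COc1cc(C(=O)N2CCN(C(=O)c3cc(OC)c(OC)c(OC)c3)C(COC(=O)C(C)(C)C)C2)cc(OC)c1OC` gives 100 nM; 100 nM; 120 nM (3 entries) in this assay, as its entries show (the several entries of compound 3 in this assay, 100 nM; 100 nM; 120 nM (3 entries)), and no single step links it to compound 2. Compound 4 `COc1cc(C(=O)N2CCN(C(=O)c3cc(OC)c(OC)c(OC)c3)C(COC(=O)C3CCCCC3)C2)cc(OC)c1OC` carries the change (cyclohexyl in place of heptyl on a carbonyl carbon). Within the data shown here, the one measured step, from compound 1 to compound 2, shows that lengthening the chain changes nothing beyond the scatter; the values of compound 3 show that a compact ester can give a lower number than either chain. For compound 4 the expected step is a 1.9-fold lower number from compound 2 to compound 4 (0.29 log units; within the scatter), and the estimate for compound 4 is 160 nM, ranging from 60 nM to 420 nM.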

Compound 4, half-maximal inhibitory concentration: 290 nM
Beside the measured number, compound 4's estimate is 1.8-fold (0.26 log units) below it; measured number inside the range.
By their numbers in this assay, from the lowest: compounds 1, 4 and 2 (each within the scatter of the next).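

In this assay, cyclohexyl in place of heptyl on the carbonyl carbon gives a 1.1-fold lower number from compound 2 to compound 4 (0.03 log units; within the scatter), and cyclohexyl in place of pentyl gives no change at the digits printed from compound 1 to compound 4 (within the scatter). At this position, a six-membered ring of carbon only therefore reads the same, within the scatter, as either linear chain. Closing the chain into this ring does not bring the number down to that of the compact ester, whose values stand apart: the several entries of compound 3 in this assay, 100 nM; 100 nM; 120 nM (3 entries)

On these data alone, it remains open whether a smaller ring such as cyclopropyl, an aromatic phenyl or an amine on this carbonyl carbon would move the number beyond the scatter.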